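The compounds below may be only part of what the source reports. "The series", "measured", "known", "first", "only" and "open" are said of these compounds alone.

Measured compounds:
compound 1 `COc1ccc(CNc2nc(SC)nc3ncccc23)cc1` — > 100000 nM
compound 2 `C[Se]c1nc([Se]C)c2cccnc2n1` — "not determined" (no result reported)
compound 3 `CCCCCSc1nc(NCc2ccc([Se]C)cc2)c2ccccc2n1` — > 100000 nM

In a functional assay on HT-29 cells (Homo sapiens) for cytotoxicity, read by MTT assay, with a stated time of 72 h (on this read-out higher numbers stand for weaker inhibition of growth and lower numbers for stronger inhibition of growth), compound 1 reaches only a limit, > 100000 nM. Compound 3 likewise gives only a limit, > 100000 nM. For compound 2 no result is reported: "not determined" (no result reported). Compound 1 therefore stands at the ceiling of the read-out, shared with compound 3 (the limit of > 100000 nM in this assay, at which 2 of the 3 values shown sit); no single number places it anywhere within the range.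

Compound 4 `CSc1nc(NCc2ccccc2)c2cccnc2n1` differs from compound 1 by hydrogen in place of methoxy on an aromatic carbon. Among the compounds with values here, no pair of measured compounds differs in one place, so no measured step guides this change; in this assay a step of no size beyond the scatter is expected, in neither direction, with a strong chance that only a limit is again reported.

Compound 4 is expected at 150000 nM. For compound 4 the expected range runs from 40000 nM to 500000 nM. The estimated step that the limit leaves unreadable from compound 1 to compound 4 amounts to essentially none.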

Compound 4, concentration for total growth inhibition: > 100000 nM
Compound 4 ended at the assay's limit (the forecaster's own chance of this, stated with the estimate: 75%); the middle value lies beyond the limit too.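

In this assay no step can be read between compound 1 and compound 4, as both give only a limit: the limit of > 100000 nM in this assay, at which 3 of the 4 values shown sit.

The compounds shown leave open whether hydrogen in place of methoxy on the aromatic carbon changes growth inhibition at all.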